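A few compounds are considered here, and "the series" means these few. Any claim that something is new, unique, unknown or untested is made for them only; others in the source may bear on it.

Working notes on the series. In an ADME assay on microsomes from liver (Homo sapiens) for metabolic stability, read by LC-MS, with a stated time of 10 min (a lower number here means that less of the compound is left, a higher number that more of the compound is left), compound 1 `C[C@@H]1CN(c2cccc3c2C[C@H](CN(C)[C@H]2CCCc4cccnc42)NC3)C[C@H](C)N1` gives 100% and compound 2 `CN(C[C@H]1Cc2c(cccc2N2CCN(C3CC3)CC2)CN1)[C@H]1CCCc2cccnc21` gives 15.5%, the lower of the two numbers. Next is compound 3 `CN(C[C@H]1Cc2c(cccc2N2CCN(c3ncccn3)CC2)CN1)[C@H]1CCCc2cccnc21`, with the change (pyrimidin-2-yl in place of cyclopropyl on an amine nitrogen in a ring), that is, pyrimidin-2-yl in place of cyclopropyl on an amine nitrogen in a ring. Going by the values given here, the one measured step that bears on this is large: a number 84.5 percentage points lower from compound 1 to compound 2 (beyond the scatter), with 4-cyclopropylpiperazin-1-yl in place of 3,5-dimethylpiperazin-1-yl on an aromatic carbon. Among the compounds with values here, it brought in the cyclopropyl that now leaves, but no measured compound carries pyrimidin-2-yl, so its size is only a loose guide. A smaller move in this assay than that step is expected, upward, with the number for compound 2 at 15.5% leaving more room in that direction. The estimated step is a number 22.5 percentage points higher from compound 2 to compound 3 (beyond the scatter). The expected value for compound 3 is 38%, within an estimated range from 10% to 78%.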

Compound 3, percent of the compound remaining: 35.5%
Beside the measured number, compound 3's estimate is 2.5 percentage points above it, and the stated range covers the measured number.
By their numbers in this assay, from the lowest: compound 2; then compound 3; then compound 1.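

In this assay, pyrimidin-2-yl in place of cyclopropyl on an amine nitrogen in a ring gives a number 20 percentage points higher from compound 2 to compound 3 (beyond the scatter). The earlier step, a number 84.5 percentage points lower from compound 1 to compound 2 (beyond the scatter), exchanged the whole 3,5-dimethylpiperazin-1-yl group, whereas this one changes only the group on that nitrogen and shows that this change alone moves the number beyond the scatter. No measurement available here accounts for the rise.

The compounds shown leave open whether the step follows the larger six-membered aromatic ring or the ring nitrogens it carries, as a phenyl group on the same nitrogen would help to separate these. Going by these compounds, how a small methyl group or an acetyl group at this nitrogen would compare with cyclopropyl and pyrimidin-2-yl also remains open.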